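Extending the amide chain on a bromo analogue

This account rests on a few compounds, and the source may have more. Where it says the series, first, only, none or still open, it means among the compounds named here.

In an assay for binding affinity to melatonin receptor (Gallus gallus) (on this read-out lower numbers stand for stronger inhibition and higher numbers for weaker inhibition), compound 1 `CCCC(=O)NCCCc1cccc(OC)c1` gives 5.5 nM. For the measured compounds named here, compound 2 `CCCC(=O)NCCCc1cccc(F)c1` gives 434 nM in this assay, and the single clean comparison among the measured compounds is a 79-fold higher number from compound 1 to compound 2 (1.90 log units; beyond the scatter). Compound 3 `CCC(=O)NCCCc1cccc(Br)c1` gives 318 nM in this assay, which places it second highest of the three numbers: its nearest neighbour is compound 2, whose value lies within the scatter of it, while compound 1 stands far lower and well beyond the scatter.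

Compound 4 `CCCC(=O)NCCCc1cccc(Br)c1` differs from compound 3 by methyl in place of hydrogen on a saturated chain carbon, two bonds along the chain from a carbonyl carbon. Going by the values given here, no measured pair isolates this change. Among the compounds with values here, the only recorded step, from compound 1 to compound 2, alters the aromatic substituent and leaves the amide chain untouched, so it carries no information about lengthening that chain. Compound 2 and compound 3 differ in two places at once, including this chain, and their values sit within the scatter of each other, which hints that the chain length matters little here, though the two changes cannot be separated.

The expected step is therefore small, a 1.4-fold lower number from compound 3 to compound 4 (0.16 log units; within the scatter), with no direction beyond the scatter asserted. Compound 4 is estimated at 220 nM, within a range from 60 nM to 800 nM.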

Compound 4, inhibition constant: 354 nM
Beside the measured number, compound 4's estimate is 1.6-fold (0.21 log units) below it; measured number inside the range.
By their numbers in this assay, from the lowest: compound 1; then compounds 3, 4 and 2 (each within the scatter of the next).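

In this assay, methyl in place of hydrogen on a saturated chain carbon, two bonds along the chain from a carbonyl carbon, can now be read on its own (a 1.1-fold higher number from compound 3 to compound 4 (0.05 log units; within the scatter)). On this bromo compound, the propanoyl and propylcarbonyl chains therefore cannot be told apart, which separates the chain change from the aromatic change that were mixed together between compound 2 and compound 3. With the propylcarbonyl chain held constant, bromo in place of fluoro also makes no difference beyond the scatter (a 1.2-fold lower number from compound 2 to compound 4 (0.09 log units; within the scatter)), while bromo in place of methoxy gives a large step (a 64-fold higher number from compound 1 to compound 4 (1.81 log units; beyond the scatter)), so among these three groups on the longer chain, the methoxy compound alone stands apart. Nothing available explains this difference between methoxy and the two halogens.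

On these data alone, it remains open whether the chain step would be equally small on the methoxy compound, whose number is much lower, or whether a longer chain than propylcarbonyl would keep the same result. An amine or a carboxylic acid on the aromatic carbon in place of bromo or methoxy would also be new ground, as the compounds here say nothing about either group.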